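Adding a Bromine to Compound 3: What to Expect

The source may report more compounds than this note shows. Statements on the series, on what has been measured and on what is new or still open speak of the compounds shown alone.

Of the compounds shown here, three have been tested in an assay for inhibition of HSP60/HSP10 (Homo sapiens), with a stated time of 60 min; on this read-out lower numbers stand for stronger inhibition and higher numbers for weaker inhibition. Compound 1 `O=C(Nc1ccccc1)c1cc(Br)ccc1O` gives > 100000 nM, which is a limit rather than a number. Compound 2 `O=C(Nc1ccc(Sc2nc3ccccc3s2)cc1)c1cc(Br)cc(Br)c1` likewise gives > 100000 nM, again only a limit. Compound 3 `COc1ccccc1C(=O)Nc1ccc(Sc2nc3ccccc3s2)cc1` also gives > 100000 nM, a limit and not a measured number. The one step that connects two of these compounds, a step that the two limits leave unreadable from compound 2 to compound 3, cannot be read in size because both of its ends sit at the limit of > 100000 nM in this assay, at which 3 of the 3 values shown sit.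

Compound 3 therefore stands where every measured compound stands: at the edge of what this assay can report, with no number of its own.

Compound 4 `COc1c(Br)cccc1C(=O)Nc1ccc(Sc2nc3ccccc3s2)cc1` differs from compound 3 by bromo in place of hydrogen on an aromatic carbon. For the measured compounds named here, no measured step bears directly on this change. Going by the values given here, the only measured step, a swap of the whole group on the carbonyl carbon, did not move the read-out off its limit, so there is no sign that a single bromine will bring compound 4 into the measurable range. The step that the limit leaves unreadable from compound 3 to compound 4 is expected to be no change beyond the scatter. Compound 4 is thus estimated at 150000 nM in this assay, with a range from 50000 nM to 500000 nM, and most likely reported again only as a limit.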

Compound 4, half-maximal inhibitory concentration: > 100000 nM
Compound 4 was reported as a limit; the forecaster's own chance of this, stated with the estimate: 85%; the middle value is on the limit's open side.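

For the compounds shown here, no step from compound 2 or compound 3 to compound 4 can be read in size, because compound 4 is again reported only as a limit, like the others: the limit of > 100000 nM in this assay, at which 4 of the 4 values shown sit. The compounds shown leave open which change in structure, if any, would bring a measured number in this assay and so make a comparison possible.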